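Triazole substituent swaps on a bromoquinoline core: cytotoxicity notes

A few compounds are considered here, and "the series" means these few. Any claim that something is new, unique, unknown or untested is made for them only; others in the source may bear on it.

Measured compounds, with their numbers in an ADME assay on PC-3 cells (Homo sapiens) for cytotoxicity, read by sulforhodamine B assay, with a stated time of 48 h, tested at 10 uM; a lower number here means less inhibition, a higher number more inhibition at the concentration tested (going by the name of the read-out):
- compound 1, `COc1nc2ccc(Br)cc2cc1C(c1ccccc1)n1cc(-c2ccc(OC(F)(F)F)cc2)nn1`: 21.6%
- compound 2, `COc1nc2ccc(Br)cc2cc1C(c1ccccc1)n1cc(CCCCCO)nn1`: 12.9%
- compound 3, `COc1nc2ccc(Br)cc2cc1C(c1ccccc1)n1cc(-c2ccc(F)cc2)nn1`: 16.4%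

Compound 3 sits between the other two: the step of a number 3.5 percentage points higher from compound 2 to compound 3 (within the scatter) and the step of a number 5.2 percentage points lower from compound 1 to compound 3 (within the scatter) are both within the scatter, so no ranking among the three can be drawn.

The next compound is compound 4, `COc1nc2ccc(Br)cc2cc1C(c1ccccc1)n1cc(CO)nn1`. Its change from compound 3 is hydroxymethyl in place of 4-fluorophenyl on an aromatic carbon. Among the measured compounds shown here, two measured steps bear on it, both replacing an aromatic group with a hydroxyalkyl chain or the reverse: a number 8.7 percentage points lower from compound 1 to compound 2 (within the scatter) and, read backwards, a number 3.5 percentage points higher from compound 2 to compound 3 (within the scatter). Both point slightly toward less inhibition when the hydroxyalkyl chain is present, yet neither leaves the scatter. The hydroxymethyl chain is shorter than the 5-hydroxypentyl of compound 2, and nothing measured separates chain lengths.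

For compound 4 in this assay a small downward step or none beyond the scatter is expected, a number 5.4 percentage points lower from compound 3 to compound 4 (within the scatter). The estimated value for compound 4 is 11%, within 3% to 22%.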

Compound 4, a percentage reported as inhibition, at one concentration (the size of the read-out at that concentration, not a potency): 4.65%
Estimate against measurement, compound 4: 6.4 percentage points above; measured number inside the range.
By their numbers in this assay, from the lowest: compounds 4, 2, 3 and 1 (each within the scatter of the next, the first and the last beyond it).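

Among the compounds shown here, at this aromatic carbon of the five-membered aromatic ring with 3 nitrogen, this assay now gives steps beyond the scatter, both on replacing an aromatic group with hydroxymethyl: a number 11.8 percentage points lower from compound 3 to compound 4 (beyond the scatter) and a number 17 percentage points lower from compound 1 to compound 4 (beyond the scatter) are the first such steps. The comparison between the two hydroxyalkyl groups does not reach that level, as a number 8.3 percentage points lower from compound 2 to compound 4 (within the scatter) leaves hydroxymethyl and 5-hydroxypentyl unresolved. No supporting measurement accounts for these steps.

The compounds shown do not separate loss of the aromatic ring from gain of the hydroxy group, and a plain pentyl chain or an unsubstituted phenyl at this carbon would bear on that. As far as these compounds go, how an amine or a carboxylic acid on a short chain here would compare with hydroxymethyl also stays open.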